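A Hydroxyl Replaces Fluorine on the Chain-Borne Ring

The source may report more compounds than this note shows. Statements on the series, on what has been measured and on what is new or still open speak of the compounds shown alone.

Compound 1 `COc1ccc(C(=O)/C=C/c2cccc(F)c2)c2c1C=CC(C)(C)O2` was tested in a functional assay on HT-29 cells (Homo sapiens) for antiproliferative activity, read by MTT assay, with a stated time of 24 h; on this read-out higher numbers stand for weaker inhibition and lower numbers for stronger inhibition. In this assay compound 1 gives only a limit, > 10000 nM, so no number is known for it. Compound 2 `COc1ccc(C(=O)/C=C/c2cccs2)c2c1C=CC(C)(C)O2` also gives only a limit in this assay, > 10000 nM. The step that the two limits leave unreadable from compound 1 to compound 2 is therefore unreadable, since both values sit at the same limit, (the limit of > 10000 nM in this assay, at which 2 of the 2 values shown sit).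

Compound 3 `COc1ccc(C(=O)/C=C/c2ccc(O)cc2)c2c1C=CC(C)(C)O2` has not yet been measured in this assay. It differs from compound 1 in one place: 4-hydroxyphenyl in place of 3-fluorophenyl on a double-bonded chain carbon bound to a double-bonded chain carbon. For the measured compounds named here, no measured step shows this change, and the one measured step, from compound 1 to compound 2, cannot be read at all, so the measurements give no direction and no size to expect beyond the scatter.

Compound 3 is expected to give about 15000 nM in this assay, with a range from 3000 nM to 80000 nM, and most likely only a limit again. The step that the limit leaves unreadable from compound 1 to compound 3 is thus estimated as no real change, resting only on the limit seen for compound 1.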

Compound 3, half-maximal inhibitory concentration: > 10000 nM
Compound 3 ended at the assay's limit (the forecaster's own chance of this, stated with the estimate: 70%); the middle value does not contradict the limit.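

Compound 3 gives only a limit in this assay, as do compound 1 and compound 2, so none of the steps among these three compounds can be read: the limit of > 10000 nM in this assay, at which 3 of the 3 values shown sit.

From the compounds shown here alone, whether any group at this place gives a readable number in this assay stays open, and so does the size of any difference among 3-fluorophenyl, thiophen-2-yl and 4-hydroxyphenyl.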